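Carbamoyl in Place of Ethyl on the Amine Chain

A few compounds are considered here, and "the series" means these few. Any claim that something is new, unique, unknown or untested is made for them only; others in the source may bear on it.

Compound 1 `CC(=O)Oc1ccc(C(=O)Nc2cc3ccc(OCCC4CCCCN4)c(C)c3oc2=O)cc1CC=C(C)C` and compound 2 `CCCNCCCOc1ccc2cc(NC(=O)c3ccc(O)c(CC=C(C)C)c3)c(=O)oc2c1C` share the same core and were tested in a functional assay on SK-BR-3 cells (Homo sapiens) for antiproliferative activity; a lower number here means a stronger inhibitor, a higher number a weaker inhibitor. In this assay compound 1 gives 640 nM, and compound 2 gives 990 nM. Compound 2 has the higher of these two numbers, but its gap to compound 1 lies within the scatter of repeated measurements, so the two cannot be ranked against each other. Compound 3 `CC(C)=CCc1cc(C(=O)Nc2cc3ccc(OCCCNCC(N)=O)c(C)c3oc2=O)ccc1O` has not been measured yet. It differs from compound 2 in one place: carbamoyl in place of ethyl on a saturated chain carbon bound to an amine nitrogen. Among the compounds with values here, no pair of measured compounds differing in a single place is known here, so there is no directly comparable step to lean on. The expectation for compound 3 is therefore a step of at most modest size in this assay, most likely toward a somewhat higher number or no change beyond the scatter. Compound 3 is expected to give 1500 nM in this assay, within 600 nM to 4000 nM, which means an estimated step of a 1.5-fold higher number from compound 2 to compound 3 (0.18 log units; within the scatter).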

Compound 3, half-maximal inhibitory concentration: 2290 nM
Compound 3: middle estimate off by 1.5-fold (0.18 log units), on the low side; measured number inside the range.
By their numbers in this assay, from the lowest: compounds 1 and 2 (each within the scatter of the next); then compound 3.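

In this assay, within the data shown here, carbamoyl in place of ethyl on a saturated chain carbon bound to an amine nitrogen produces a 2.3-fold higher number from compound 2 to compound 3 (0.36 log units; beyond the scatter) and gives the first single-place comparison. It shows that the group at this place on the amine chain can alter the result, although this modest loss leaves compound 3 still active in the assay. No measurement here bears on what lies behind this shift.

Carbamoyl carries a hydrogen-bond donor and a hydrogen-bond acceptor, while ethyl carries neither, but one step cannot show whether either feature matters or whether the change in the group's size or shape is what counts. A carboxylic acid, a hydroxyl or a longer alkyl chain at the same place would help separate these possibilities.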